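The compounds below may be only part of what the source reports. "The series", "measured", "known", "first", "only" and "open" are said of these compounds alone.

Measured in a physicochemical assay for lipophilicity, at pH 7.4; on this read-out lower numbers stand for lower lipophilicity and higher numbers for higher lipophilicity:
- Compound 1 `CNC(=O)c1cc(C(=O)NC2CC2)cn(CC2CCCCC2)c1=O`: 4
- Compound 2 `CNC(=O)c1cc(C(=O)NC2CC2)cn(Cc2cccc3[nH]ccc23)c1=O`: 2.9
- Compound 3 `CNC(=O)c1cc(C(=O)NC2CC2)cn(Cc2nccc3[nH]ccc23)c1=O`: 1.7

Compound 3 is the lowest of the three on this assay. Compound 4 `CNC(=O)c1cc(C(=O)NC2CC2)cn(Cc2cccc3cn[nH]c23)c1=O` has the same atoms joined differently: a group of 9 heavy atoms (7 carbon, 2 nitrogen; one five-membered aromatic ring with 2 hetero atoms, one six-membered aromatic ring of carbon only) in place of a group of 9 heavy atoms (7 carbon, 2 nitrogen; one five-membered aromatic ring with 1 hetero atom, one six-membered aromatic ring with 1 hetero atom), on a saturated chain carbon bound to an aromatic nitrogen. The closest measured guide is a number 1.20 log units lower from compound 2 to compound 3 (beyond the scatter), a large step that brought in a six-membered aromatic ring with 1 hetero atom. Among the measured compounds shown here, compound 4 returns to a six-membered aromatic ring of carbon only, but its five-membered aromatic ring has 2 hetero atoms, a feature no measured compound shows. A clear rise is therefore expected, smaller than that large step. The expected step is a number 0.80 log units higher from compound 3 to compound 4 (beyond the scatter). Compound 4 is estimated at 2.5, with an expected range of 2.1 to 2.9.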

Compound 4, distribution coefficient: 2.2
Beside the measured number, compound 4's estimate is 0.30 log units above it, within the range that was stated.
By their numbers in this assay, from the lowest: compound 3; then compound 4; then compound 2; then compound 1.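

Compound 4 shows that at this saturated chain carbon bound to an aromatic nitrogen, this assay responds to how the same atoms are joined, with a number 0.50 log units higher from compound 3 to compound 4 (beyond the scatter). A lower number does not need a hetero atom in the six-membered ring: 1H-indazol-7-yl, whose six-membered aromatic ring is carbon only, gives a number 0.70 log units lower from compound 2 to compound 4 (beyond the scatter) and a number 1.80 log units lower from compound 1 to compound 4 (beyond the scatter). No measurement given here accounts for these steps. Still open, as far as these compounds go, is how an amine or a carboxylic acid on the 1H-indazol-7-yl group would shift this read-out.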